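The compounds below may be only part of what the source reports. "The series", "measured", "known", "first", "only" and "open" are said of these compounds alone.

Compound 2 `O=S(=O)(O)CCCNC[C@@H]1CCCc2cc(S(=O)(=O)c3cccc(F)c3)ccc21` holds the highest number of the two measured in an assay on isolated protein for displacement of a labelled ligand from 5-hydroxytryptamine receptor 6 (Homo sapiens); a higher number here means a weaker inhibitor, a lower number a stronger inhibitor: compound 2 gives 1.26 nM, while compound 1 `NC(=O)CNC[C@@H]1CCCc2cc(S(=O)(=O)c3cccc(F)c3)ccc21` gives 0.1 nM. Compound 3 `NC(=O)NC[C@@H]1CCCc2cc(S(=O)(=O)c3cccc(F)c3)ccc21` is not yet measured; it differs from compound 2 by carbamoyl in place of 3-sulfopropyl on an amine nitrogen. Among the measured compounds shown here, the one step on record bears on it in reverse: a 13-fold higher number from compound 1 to compound 2 (1.10 log units; beyond the scatter). Replacing the 3-sulfopropyl with a carbamoyl brings compound 3 nearer to compound 1, so a move back toward the lower number is expected, roughly a 4.2-fold lower number from compound 2 to compound 3 (0.62 log units; beyond the scatter). For compound 3 in this assay the estimate is 0.3 nM, expected to fall between 0.08 nM and 1.2 nM.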

Compound 3, inhibition constant: 0.2 nM
For compound 3 the middle estimate is 1.5-fold (0.18 log units) above the measured one; the range from low to high includes it.
By their numbers in this assay, from the lowest: compounds 1 and 3 (each within the scatter of the next); then compound 2.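

In this assay, carbamoyl on the amine nitrogen gives a clear gain over 3-sulfopropyl, a 6.3-fold lower number from compound 2 to compound 3 (0.80 log units; beyond the scatter). Carbamoyl in place of carbamoylmethyl at the same nitrogen gives a 2.0-fold higher number from compound 1 to compound 3 (0.30 log units; within the scatter), so this position tolerates both of these carbamoyl-bearing substituents and the assay does not separate them. No available evidence accounts for either step.

Going by these compounds, whether the weaker number of compound 2 follows from the sulfonic acid or from the chain length remains open. A carboxylic acid on the same three-carbon chain, a longer chain ending in carbamoyl, or the plain primary amine would help to separate these.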